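A few compounds are considered here, and "the series" means these few. Any claim that something is new, unique, unknown or untested is made for them only; others in the source may bear on it.

This account follows one change to a shared core. Going by the values given here, compound 3 `Cc1c(COc2cccc(OCC3CCOCC3)c2)[nH]c2ccccc2c1=O` is the starting point: in an in vitro ADME assay on microsomes from liver (Mus musculus) for metabolic stability, tested at 0.2 uM (a lower number here means slower removal, a higher number faster removal of the compound), compound 3 gives 420 mL/min/kg, which is the only single number among the three measured compounds. Compound 1 `O=c1c(Cl)c(COc2cccc(OCC3CCOCC3)c2)[nH]c2ccccc12` differs from compound 3 by a chloro where compound 3 carries a methyl. In this assay compound 1 reaches only a limit of the assay, > 1000 mL/min/kg. Compound 2 `CC(C)c1c(COc2cccc(OCC3CCOCC3)c2)[nH]c2ccccc2c1=O` belongs to the same series, and in this assay compound 2 has "not determined" (no result reported). Among the compounds with values here, the single measured step, an at least 2.3-fold lower number from compound 1 to compound 3 (0.37 log units; beyond the scatter), is therefore the only guide, and it rests on one side on a limit, (the limit of > 1000 mL/min/kg in this assay, at which 1 of the 3 values shown sits).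

Compound 4 `O=c1cc(COc2cccc(OCC3CCOCC3)c2)[nH]c2ccccc12` differs from compound 3 by hydrogen in place of methyl on an aromatic carbon. Within the data shown here, no measured step removes a substituent in this way; the one known step swaps chloro for methyl on an aromatic carbon, so it speaks only indirectly to compound 4. With so little to go on, a shift in clearance of no more than modest size in either direction is expected, and a larger one cannot be ruled out. For compound 4 the expected step is a 1.1-fold higher number from compound 3 to compound 4 (0.06 log units; within the scatter). Compound 4 is accordingly estimated at 480 mL/min/kg, with a range from 200 mL/min/kg to 1100 mL/min/kg.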

Compound 4, clearance: 197 mL/min/kg
For compound 4 the middle estimate is 2.4-fold (0.39 log units) above the measured one; measured number outside the range, below it.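

Taking the methyl off this aromatic carbon, two atoms from the ring nitrogen, gives in this assay a 2.1-fold lower number from compound 3 to compound 4 (0.33 log units; beyond the scatter), so this position responds when a substituent is removed and not only when one group is swapped for another. Compound 4, with plain hydrogen here, also stands clear of the chloro compound, with an at least 5.0-fold lower number from compound 1 to compound 4 (0.70 log units; beyond the scatter), and the three groups now fall in the order hydrogen, methyl, chloro, from the lowest number to the highest. The value of compound 1 is a limit, so this last step gives only a minimum size: the limit of > 1000 mL/min/kg in this assay, at which 1 of the 4 values shown sits.

Going by these compounds, three groups at one position on one core make a short series, and the steps to compound 2 cannot be read, so it remains unknown whether the order would hold for other groups, including the isopropyl of compound 2. On these data alone, it also remains open whether a fluoro, a methoxy or an amine on this carbon would fall near hydrogen, near methyl or beyond chloro in clearance.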